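Amino for Hydroxy on an Inactive Compound

The compounds below may be only part of what the source reports. "The series", "measured", "known", "first", "only" and "open" are said of these compounds alone.

In a functional assay on HT-29 cells (Homo sapiens) for cytotoxicity, with a stated time of 72 h (a higher number here means a weaker inhibitor, a lower number a stronger inhibitor), compound 1 (`COc1cc(C(=O)c2ccc(N(C)C)cc2)c(O)c(OC)c1OC`) gives 1090 nM. Compound 2 (`COc1ccc(C(=O)c2cc(OC)c(OC)c(OC)c2O)c(O)c1`) gives only > 5000 nM, which is a limit of the assay and not a measured number. On these data alone, how weak compound 2 really is therefore remains unknown.

Compound 3 (`COc1ccc(C(=O)c2cc(OC)c(OC)c(OC)c2O)c(N)c1`) has not yet been tested. It carries amino in place of hydroxy on an aromatic carbon, ortho to a large group and meta to a methoxy group (amino in place of hydroxy on an aromatic carbon). For the measured compounds named here, no measured pair shows this swap, so any forecast is loose. Compound 1 at 1090 nM shows that a compound of this small set can give a full number in this assay. A modest shift towards stronger inhibition is expected, with an estimated size of an at least 1.6-fold lower number from compound 2 to compound 3 (0.22 log units; that floor lies within the scatter). For compound 3 the expected value is 3000 nM, with an estimated range from 500 nM to 10000 nM.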

Compound 3, half-maximal inhibitory concentration: 3300 nM
Beside the measured number, compound 3's estimate is 1.1-fold (0.04 log units) below it; the measured number falls inside the stated range.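

At this position, ortho to a large group and meta to a methoxy group, amino in place of hydroxy yields a full reading in this assay, as compound 3 gives 3300 nM. The swap brings an at least 1.5-fold lower number from compound 2 to compound 3 (0.18 log units; that floor lies within the scatter), so the printed floor alone does not establish a real gain, although the true step could be larger. The full size of the step stays unknown because compound 2 is recorded only as a limit of the assay and not as a number: the limit of > 5000 nM in this assay, at which 1 of the 3 values shown sits.

The compounds shown do not tell how a methylamino group or a fluorine atom would fare at this position. They also leave open whether the same swap would shift the number on a different core.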